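A few compounds are considered here, and "the series" means these few. Any claim that something is new, unique, unknown or untested is made for them only; others in the source may bear on it.

Working notes on a small set of isatin-type compounds carrying a substituted quinoline through a piperazine methylene linker. Two cores are present. Compound 1 `O=C1C(=O)N(CN2CCN(c3ccnc4cc(Cl)ccc34)CC2)c2cccc(Cl)c21` and compound 2 `O=C1C(=O)N(CN2CCN(c3ccnc4cc(Cl)ccc34)CC2)c2cc(Cl)ccc21` contain the same atoms joined differently; the difference between the two cores is not broken down here. Compound 3 `O=C1C(=O)N(CN2CCN(c3ccnc4cc(C(F)(F)F)ccc34)CC2)c2cccc(Cl)c21` comes from compound 1 by trifluoromethyl in place of chloro on an aromatic carbon. Compound 4 `O=C1C(=O)N(CN2CCN(c3ccnc4cc(C(F)(F)F)ccc34)CC2)c2cc(Cl)ccc21` comes from compound 2 by trifluoromethyl in place of chloro on an aromatic carbon, the same change carried out on the other core, with the surroundings of the place described identically for both pairs.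

In a functional assay on MDA-MB-468 cells (Homo sapiens) for cytotoxicity, read by sulforhodamine B assay, with a stated time of 48 h (on this read-out lower numbers stand for stronger inhibition of growth and higher numbers for weaker inhibition of growth), compound 1 gives 37800 nM, compound 2 gives 36600 nM and compound 3 gives 28400 nM. The measured step from compound 1 to compound 3 is a 1.3-fold lower number from compound 1 to compound 3 (0.12 log units; within the scatter). The values of compound 1 and compound 2 lie within the scatter of each other, so the two cores are not separated on this read-out; compound 3 and compound 2 are likewise within the scatter of each other. All three numbers sit in the same weak range.

Compound 4 remains to be measured in this assay. Going by the values given here, only one instance of the change is available, and that instance stayed within the scatter, so a small step is expected here as well. The expected step is a 1.3-fold lower number from compound 2 to compound 4 (0.10 log units; within the scatter), set beside a 1.3-fold lower number from compound 1 to compound 3 (0.12 log units; within the scatter), and it rests on that single measured instance. Compound 4 is accordingly expected to give about 29000 nM, with a plausible range from 14000 nM to 58000 nM.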

Compound 4, concentration for 50% growth inhibition: 26100 nM
Compound 4: the middle estimate sits 1.1-fold (0.05 log units) above what was measured; low and high end bracket the measured number.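

In this assay, trifluoromethyl in place of chloro on the second core gives a 1.4-fold lower number from compound 2 to compound 4 (0.15 log units; within the scatter), so the step stays small on this core as well. Set side by side, the two instances of the change agree: the same change on two cores in this assay, a 1.3-fold lower number (0.12 log units; within the scatter) from compound 1 to compound 3 and a 1.4-fold lower number (0.15 log units; within the scatter) from compound 2 to compound 4, 1.1-fold (0.02 log units) apart, within the scatter of two such steps. This shows only that, on these two cores, the change gives a step too small to read, and the agreement is between two steps that cannot be told from repeat scatter; it does not show a real gain from trifluoromethyl over chloro, nor that a step of readable size would carry from one core to the other.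

At the place of the change, the compounds shown carry only chloro or trifluoromethyl, so it remains open whether an amine, a methoxy group or a carboxylic acid there would move the numbers out of the weak range in which all four compounds sit. Also open, on these data alone, is whether a longer chain in place of the methylene linker would shift that range, and whether the two cores would still stay together once a step stands clear of the scatter.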